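Replacing an Aromatic Ring with Cyclohexyl on the Amide

The source may report more compounds than this note shows. Statements on the series, on what has been measured and on what is new or still open speak of the compounds shown alone.

Of the compounds shown here, two with the same core have been measured so far. In a functional assay on THP-1 cells (Homo sapiens) for cytotoxicity, read by MTT assay, with a stated time of 24 h (a higher number here means a weaker inhibitor, a lower number a stronger inhibitor), compound 1 `Nc1nn(Cc2cn(CC(=O)Nc3cccc(F)c3)nn2)c2nc(-c3ccccc3)cc(C(F)(F)F)c12` gives 99.5 ug/mL and compound 2 `Nc1nn(Cc2cn(CC(=O)Nc3ccccc3Br)nn2)c2nc(-c3ccccc3)cc(C(F)(F)F)c12` gives 95.3 ug/mL on the same scale. Going by the values given here, compound 2 thus stands level with the only other measured compound, as the single measured step is a 1.0-fold lower number from compound 1 to compound 2 (0.02 log units; within the scatter) and exchanges one substituted phenyl group for another.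

The next structure is compound 3 `Nc1nn(Cc2cn(CC(=O)NC3CCCCC3)nn2)c2nc(-c3ccccc3)cc(C(F)(F)F)c12` with cyclohexyl in place of 2-bromophenyl on an amide-type nitrogen and no other change. The ring that enters is a six-membered non-aromatic ring of carbon only, a kind of group that neither measured compound carries at this place. Among the compounds with values here, the one measured step therefore offers only weak guidance, and the data hold no direct precedent for this swap.

With so little evidence, the best starting point is compound 2 at 95.3 ug/mL and no shift beyond the scatter is expected in this assay for now. The estimated step is a 1.1-fold lower number from compound 2 to compound 3 (0.02 log units; within the scatter) in this reading. For compound 3 the expected value is 90 ug/mL with an estimated range from 50 ug/mL to 170 ug/mL for a single measurement.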

Compound 3, half-maximal inhibitory concentration: 64.8 ug/mL
The estimate for compound 3 lay 1.4-fold (0.14 log units) above the measured number, within the range that was stated.
By their numbers in this assay, from the lowest: compounds 3, 2 and 1 (each within the scatter of the next).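

Going by these compounds alone, at the amide-type nitrogen, the earlier compounds offered only a comparison of one halogen-bearing phenyl group with another, whereas compound 3 brings a non-aromatic ring to this place for the first time. In this assay, this change reads as a 1.5-fold lower number from compound 2 to compound 3 (0.17 log units; within the scatter) and, when 3-fluorophenyl is the group replaced, as a 1.5-fold lower number from compound 1 to compound 3 (0.19 log units; within the scatter), so neither comparison separates cyclohexyl from the phenyl groups it replaces. Across these three compounds, then, the aromatic ring and its halogen can both give way to cyclohexyl with no difference beyond the usual spread of repeated measurements, and no supporting measurement is available to explain the numbers.

Still open, going by these compounds, is whether a plain phenyl group carrying no halogen, or an open chain such as n-butyl in place of a ring, would stay level with these three compounds. It is also unknown whether adding an amine or a carboxylic acid to the cyclohexyl ring would move the number in this assay beyond that spread, which would show that this position can influence the reading at all.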